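This account rests on a few compounds, and the source may have more. Where it says the series, first, only, none or still open, it means among the compounds named here.

Measured compounds:
compound 1 `CCN1CCN(CCCn2cnc3c(N4CCN(CC)CC4)nc(N4CCCC4)nc32)CC1` — 500 nM
compound 2 `CN(C)Cc1ccc(CNc2nc(N3CCN(C4CCCC4)CC3)c3ncn(CCCN4CCCC4)c3n2)cc1` — 7 nM

In an assay on HEK293 cells for antagonist activity at Toll-like receptor 9 (Homo sapiens), read by spectrophotometry (on this read-out lower numbers stand for stronger inhibition and higher numbers for weaker inhibition), compound 2 gives 7 nM, the lowest of the two numbers shown. Its nearest neighbour is compound 1, which in this assay gives 500 nM, a much higher figure, and the gap between the two lies beyond the scatter. Among the measured compounds shown here, no step between compounds that differ in a single place has been measured, so the size of any one change here is not known.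

Compound 3 `COc1ccc(CNc2nc(N3CCN(C4CCCC4)CC3)c3ncn(CCCN4CCCC4)c3n2)cc1` has not yet been measured. It differs from compound 2 in one place: methoxy in place of (dimethylamino)methyl on an aromatic carbon. For the measured compounds named here, with no measured step of this kind available, the expectation rests on compound 2 and the fact that it gives 7 nM, the lowest value shown. The step from compound 2 to compound 3 is expected to be a 2.9-fold higher number from compound 2 to compound 3 (0.46 log units; beyond the scatter), a modest move toward weaker inhibition that may or may not exceed the scatter. Compound 3 is estimated at 20 nM, within a range from 5 nM to 80 nM.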

Compound 3, half-maximal inhibitory concentration: 240 nM
Beside the measured number, compound 3's estimate is 12-fold (1.08 log units) below it; measured number above the stated range.
By their numbers in this assay, from the lowest: compound 2; then compound 3; then compound 1.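

In this assay, putting methoxy in place of (dimethylamino)methyl on the aromatic carbon para to a large group gives a 34-fold higher number from compound 2 to compound 3 (1.54 log units; beyond the scatter), the only step shown that changes a single place, and it is large. It shows that this position of the six-membered aromatic ring is not indifferent to its substituent, even though the group leaving and the group entering count the same hydrogen-bond donors and acceptors and neither carries a net charge. Nothing available explains the size of this step.

The compounds shown leave open whether aminomethyl, a longer chain ending in dimethylamino, or morpholinomethyl at this position would stay close to compound 2. They also do not tell whether the gap comes from losing the amine nitrogen or from the shorter group.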